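Adding a Third Methoxy to the Carbonyl-Side Ring

This account rests on a few compounds, and the source may have more. Where it says the series, first, only, none or still open, it means among the compounds named here.

Of the compounds shown here, two of a shared core have been measured so far in a functional assay on UACC-257 cells (Homo sapiens) for inhibition, read by sulforhodamine B assay, with a stated time of 48 h; on this read-out higher numbers stand for weaker inhibition of growth and lower numbers for stronger inhibition of growth. Compound 1 `COc1cc(-c2cc(/C=C/C(=O)c3ccc(Cl)c(Cl)c3)[nH]n2)cc(OC)c1OC` gives 16300 nM in this assay. Compound 2 `COc1ccc(C(=O)/C=C/c2cc(-c3cc(OC)c(OC)c(OC)c3)n[nH]2)cc1OC` gives 1490 nM in this assay, the lowest of the two numbers; its nearest neighbour is compound 1, and the step of an 11-fold lower number from compound 1 to compound 2 (1.04 log units; beyond the scatter).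

Compound 3 `COc1cc(C(=O)/C=C/c2cc(-c3cc(OC)c(OC)c(OC)c3)n[nH]2)cc(OC)c1OC` has not yet been measured in this assay. It differs from compound 2 in one place: methoxy in place of hydrogen on an aromatic carbon, so the carbonyl-side ring of compound 3 carries three methoxy groups where that of compound 2 carries two.

Among the compounds with values here, only one measured step exists, and it concerns a different change: an 11-fold lower number from compound 1 to compound 2 (1.04 log units; beyond the scatter). That step shows that the carbonyl-side ring matters a great deal for this assay, but it gives no direct guide to adding a single methoxy on that ring. Without a comparable precedent, the expected change is modest. Compound 3 is therefore estimated at 1000 nM in this assay, within a range of 300 nM to 4000 nM, which means an expected step of a 1.5-fold lower number from compound 2 to compound 3 (0.17 log units; within the scatter).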

Compound 3, concentration for 50% growth inhibition: 1570 nM
Compound 3: the middle estimate sits 1.6-fold (0.20 log units) below what was measured, and the stated range covers the measured number.
By their numbers in this assay, from the lowest: compounds 2 and 3 (each within the scatter of the next); then compound 1.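

In this assay the step is a 1.1-fold higher number from compound 2 to compound 3 (0.02 log units; within the scatter) and so compounds 2 and 3 cannot be told apart. Methoxy in place of hydrogen at this position, ortho to a methoxy group and meta to a large group, therefore gives no measurable difference on the carbonyl-side ring. The same ring gave a clear difference in the other step, an 11-fold lower number from compound 1 to compound 2 (1.04 log units; beyond the scatter) and so a change on this ring can matter a great deal or not at all, depending on the change. No supporting data are available to explain this contrast.

Within the data shown here, the pair tests only one incoming group at this one position, so it remains open whether a hydroxyl, an amine, a carboxylic acid or a longer chain such as ethoxy would also stay within the scatter of compound 2 or would move the number beyond it. Also open, from the compounds shown here alone, is whether the same substitution would read the same way on a carbonyl-side ring without the neighbouring methoxy groups, since both compounds of this pair carry them.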